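Swapping Chloro for Hydroxy on the Phenyl Urea

The source may hold more compounds than are shown below. What is called first, only, known or untested is meant among the compounds shown, and "the series" means these compounds.

Compound 3 `COc1cc(NC(C)CCCNC(=O)Nc2cccc(Cl)c2)c2ncccc2c1` gives 22000 nM in a functional assay on CCRF-CEM cells (Homo sapiens) for inhibition, read by MTT assay, with a stated time of 72 h (a lower number here means a stronger inhibitor, a higher number a weaker inhibitor), and holds the lowest number among the three measured compounds. Compound 1 `COc1cc(NC(C)CCCNC(=O)NNC(=O)Nc2ccc(O)cc2)c2ncccc2c1` gives 111000 nM, and compound 2 `COc1cc(NC(C)CCCNC(=O)NNC(=O)Nc2cccc(Cl)c2)c2ncccc2c1` gives 81000 nM. The steps of a 5.0-fold lower number from compound 1 to compound 3 (0.70 log units; beyond the scatter) and a 3.7-fold lower number from compound 2 to compound 3 (0.57 log units; beyond the scatter) set compound 3 apart from both, whereas a 1.4-fold lower number from compound 1 to compound 2 (0.14 log units; within the scatter) stays within the scatter.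

Compound 4 `COc1cc(NC(C)CCCNC(=O)Nc2cccc(O)c2)c2ncccc2c1` differs from compound 3 in one place: hydroxy in place of chloro on an aromatic carbon, so the (3-chlorophenyl)amino group becomes (3-hydroxyphenyl)amino. Among the compounds with values here, only one measured step bears on such an exchange of a chloro for a hydroxy on the phenyl: a 1.4-fold lower number from compound 1 to compound 2 (0.14 log units; within the scatter), which lay within the scatter, although in that pair the phenyl sits on a ((3-chlorophenyl)carbamoyl)amino or ((4-hydroxyphenyl)carbamoyl)amino unit rather than directly on the urea of compound 3. Within the data shown here, no measured step covers the change on the shorter urea itself. It is therefore expected that compound 4 shows no shift beyond the scatter, with at most a slight lean toward a higher number, estimated as a 1.4-fold higher number from compound 3 to compound 4 (0.13 log units; within the scatter). Compound 4 is estimated at 30000 nM, within a range from 12000 nM to 80000 nM.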

Compound 4, half-maximal inhibitory concentration: 32000 nM
Compound 4: the middle estimate sits 1.1-fold (0.03 log units) below what was measured, within the range that was stated.
By their numbers in this assay, from the lowest: compounds 3 and 4 (each within the scatter of the next); then compounds 2 and 1 (each within the scatter of the next).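

On the shorter urea, the same position now carries either group: hydroxy in place of chloro gives a 1.5-fold higher number from compound 3 to compound 4 (0.16 log units; within the scatter) in this assay, whereas the earlier exchange compared 3-chlorophenyl with 4-hydroxyphenyl on the longer unit. The lower numbers of the shorter urea also hold with hydroxy on the phenyl, as shown by a 2.5-fold lower number from compound 2 to compound 4 (0.40 log units; beyond the scatter) and by a 3.5-fold lower number from compound 1 to compound 4 (0.54 log units; beyond the scatter), so among these compounds they do not depend on the chloro. Nothing available here explains these numbers.

Going by these compounds, whether an amine or a carboxylic acid in place of the hydroxy of compound 4 would stay as close to compound 3 remains open. So does the outcome of a longer chain in place of the one carrying the urea.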